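A few compounds are considered here, and "the series" means these few. Any claim that something is new, unique, unknown or untested is made for them only; others in the source may bear on it.

As far as these compounds go, in a functional assay on MDA-MB-468 cells (Homo sapiens) for antiproliferative activity (a higher number here means a weaker inhibitor, a lower number a stronger inhibitor), compound 2 `CC(=O)N(C(C)=O)c1ccc(-c2nc3ccccc3s2)cc1` gives > 100 nM, which is a limit and not a number, so its exact standing remains open. Compound 3 `CC(=O)N(C(C)=O)c1ccc(-c2nc3ccccc3s2)cc1C` differs from it by methyl in place of hydrogen on an aromatic carbon, ortho to a diacetylamino group. Among the compounds with values here, no measured pair isolates this change. Compound 1 `CC(=O)Nc1ccc(-c2nc3ccccc3s2)cc1C` also carries this methyl, and its limit is > 10000 nM. On that basis, the expected step that the limit leaves unreadable from compound 2 to compound 3 is toward weaker inhibition, with low confidence in its size. For compound 3 the estimated value is 1000 nM, within an expected range of 50 nM to 10000 nM.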

Compound 3, half-maximal inhibitory concentration: > 10000 nM
Compound 3: a limit, no number; the forecaster's own chance of this, stated with the estimate: 50%; middle value at least 10-fold (1.00 log units) from the limit.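

All three values are limits, so the steps from compound 2 to compound 3 and from compound 1 to compound 3 cannot be read. As far as these compounds go, the size of either change, methyl or acetyl, remains open.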